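One inverted ring stereocentre, no precedent among measured compounds

The source may hold more compounds than are shown below. What is called first, only, known or untested is meant among the compounds shown, and "the series" means these compounds.

Measured so far:
compound 1 `COC[C@H]1O[C@H](OCc2ccc3ccccc3c2)[C@H](NC(=O)CCCN=C(N)N)[C@@H](OCc2ccc(Cl)cc2)[C@@H]1O`: 920 nM
compound 2 `COC[C@H]1O[C@H](OCCc2ccccc2)[C@H](NC(=O)CCCN=C(N)N)[C@@H](OCc2ccc(Cl)cc2)[C@@H]1O`: 540 nM

In an assay on CHO cells for displacement of a labelled ligand from melanin-concentrating hormone receptor 1 (Homo sapiens), read by scintillation counting (on this read-out higher numbers stand for weaker inhibition and lower numbers for stronger inhibition), compound 1 gives 920 nM, and compound 2 gives 540 nM. Among the measured compounds shown here, the only measured step between them, a 1.7-fold lower number from compound 1 to compound 2 (0.23 log units; within the scatter), lies within the scatter, so the two numbers cannot be told apart and compound 1 holds no distinct place among them.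

Compound 3 `COC[C@H]1O[C@@H](OCc2ccc3ccccc3c2)[C@H](NC(=O)CCCN=C(N)N)[C@@H](OCc2ccc(Cl)cc2)[C@@H]1O` has not been measured. It relates to compound 1 as follows: the two compounds have the same atoms and bonds and differ only in configuration as drawn: 1 of 5 stereo elements differ; a stereocentre at a saturated ring carbon is drawn S in compound 1 and R in compound 3. For the measured compounds named here, neither measured compound differs from another in configuration alone; the single known step exchanges a group on a side chain, so it says nothing about how a change at a ring stereocentre plays out. The expected step of a 1.6-fold higher number from compound 1 to compound 3 (0.21 log units; within the scatter) is therefore set near no change, but with a wide range to either side. Compound 3 is estimated at 1500 nM in this assay, between 300 nM and 8000 nM.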

Compound 3, half-maximal inhibitory concentration: 1750 nM
For compound 3 the middle estimate is 1.2-fold (0.07 log units) below the measured one; measured number inside the range.
By their numbers in this assay, from the lowest: compounds 2, 1 and 3 (each within the scatter of the next, the first and the last beyond it).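

Among the compounds shown here, the step of a 1.9-fold higher number from compound 1 to compound 3 (0.28 log units; within the scatter) in this assay is the first reading of configuration alone, and it lies within the scatter. At this saturated ring carbon, then, S and R cannot be told apart in this assay, at least when the naphthalen-2-yl group is present. Whatever small gap the two numbers show can be assigned to no other part of the structure, because nothing else separates the pair: the fact that compounds 1 and 3 differ only in the configuration as drawn.

This single pair cannot show whether the same inversion would stay as quiet with the side chain of compound 2, or with an amine or a carboxylic acid in place of the guanidine. As far as these compounds go, the other four stereo elements also remain unexplored, so the result speaks for this one ring carbon only.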